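A few compounds are considered here, and "the series" means these few. Any claim that something is new, unique, unknown or untested is made for them only; others in the source may bear on it.

Working notes on the steryl-sulfatase series built on the shared core of compound 1, `CCN(Cc1cccc(Br)c1)c1ccc(C(=O)N2CCc3ccc(OS(N)(=O)=O)cc3C2)cc1`. Going by the values given here, in an assay on HEK293 cells for inhibition of Steryl-sulfatase (Homo sapiens), tested at 1 uM (a higher number here means a stronger effect of the compound at the concentration tested, a lower number a weaker effect), compound 1 gives 97.2%, the highest of the three numbers so far. Compound 2, `CN(C)CCCN(Cc1ccccc1)c1ccc(C(=O)N2CCc3ccc(OS(N)(=O)=O)cc3C2)cc1`, gives 61.6% in this assay, a value well beyond the scatter below compound 1. Compound 3, `NS(=O)(=O)Oc1ccc2c(c1)CN(C(=O)c1cccc(N3CCC(N4CCCCC4)CC3)c1)CC2`, gives 8% in this assay, the furthest from compound 1 and again beyond the scatter. Among the compounds with values here, no pair of measured compounds differs in a single place, so no measured step can be drawn between them.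

The next compound, compound 4, `CCCN(CCC)c1ccc(C(=O)N2CCc3ccc(OS(N)(=O)=O)cc3C2)cc1`, differs from compound 1 in one place: dipropylamino in place of (3-bromobenzyl)(ethyl)amino on an aromatic carbon. The group that enters has no ring and fewer heavy atoms than the one that leaves, and the position on the aromatic carbon, para to a large group, is kept.

The expected step from compound 1 to compound 4 is estimated at a number 29.2 percentage points lower from compound 1 to compound 4 (beyond the scatter), downward and beyond the scatter, because compound 2, which also keeps a nitrogen substituent at this place but not the same one, gives only 61.6%. For compound 4 the expected inhibition in this assay is estimated at 68%, with a range from 40% to 92%.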

Compound 4, a percentage reported as inhibition, at one concentration (the size of the read-out at that concentration, not a potency): 84.7%
Estimate against measurement, compound 4: 16.7 percentage points below; the range from low to high includes it.
By their numbers in this assay, from the lowest: compound 3; then compound 2; then compound 4; then compound 1.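

The step of a number 12.5 percentage points lower from compound 1 to compound 4 (beyond the scatter) shows that, in this assay, the aromatic ring and the bromine of the leaving group are not needed for a high read-out at this position on the aromatic carbon, para to a large group. With dipropylamino, which has no ring and fewer heavy atoms than (3-bromobenzyl)(ethyl)amino, compound 4 still gives 84.7% at the single concentration tested, although the loss is beyond the scatter. No measured evidence accounts for the size of this step.

The change removes the bromine and the aromatic ring and alters the alkyl chains all at once, so the compounds shown do not assign the loss to any one of these parts. Open questions are how benzyl(ethyl)amino without the bromine would read at this place, which would isolate the halogen, and whether a longer chain such as dibutylamino or a cyclic amine such as piperidine would hold the read-out of compound 4.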